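The source may hold more compounds than are shown below. What is called first, only, known or untested is meant among the compounds shown, and "the series" means these compounds.

Compound 3 `COc1ccc(C)cc1NC(=O)CN1CCN(S(=O)(=O)N2CCC(C)CC2)CC1` sits at a limit in an assay on HEK293 cells for inhibition of potassium channel subfamily T member 1 (Homo sapiens), read by thallium flux; a lower number here means a stronger inhibitor, a higher number a weaker inhibitor: compound 3 gives > 10000 nM, which is a limit of the assay and not a number. Compound 1 `COc1ccccc1NC(=O)CN1CCN(S(=O)(=O)N2CCC(C)CC2)CC1` likewise reaches only a limit in this assay, with compound 1 giving > 10000 nM. Among the measured compounds shown here, the single step that joins them, a step that the two limits leave unreadable from compound 1 to compound 3, cannot be read because both of its ends sit at the limit of > 10000 nM in this assay, at which 2 of the 3 values shown sit. Compound 2 `CC1CCN(S(=O)(=O)N2CCN(CC(=O)Nc3cc(Cl)ccc3OC(C)C)CC2)CC1` gives 5100 nM in this assay. Compound 4 `Cc1ccc(Cl)cc1NC(=O)CN1CCN(S(=O)(=O)N2CCC(C)CC2)CC1` differs from compound 3 by 5-chloro-2-methylphenyl in place of 2-methoxy-5-methylphenyl on an amide-type nitrogen. For the measured compounds named here, no measured step covers this exchange; only compound 2, which also carries chlorine, yields a readable number. Compound 4 is therefore expected to remain weak, with an estimated step of an at least 1.2-fold lower number from compound 3 to compound 4 (0.09 log units; that floor lies within the scatter) and an expected value of 8000 nM, between 3000 nM and 20000 nM.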

Compound 4, half-maximal inhibitory concentration: > 10000 nM
Compound 4 gave a limit, no number; the forecaster's own chance of this, stated with the estimate: 50%; at least 1.2-fold (0.09 log units) between middle value and limit.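

Compound 4 keeps the chlorine of compound 2 but has methyl in place of isopropoxy on an aromatic carbon, and in this assay this gives an at least 1.9-fold higher number from compound 2 to compound 4 (0.29 log units; that floor lies within the scatter). Chlorine on the ring therefore does not by itself give a readable number. The steps joining compound 4 to compound 1 and compound 3 cannot be read, because all three compounds sit at a limit: the limit of > 10000 nM in this assay, at which 3 of the 4 values shown sit.

Going by these compounds, whether the readable number of compound 2 depends on isopropoxy remains open. So does whether ethoxy or a cyclopropyloxy group on that aromatic carbon would also give one.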